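Adding one fluoro to compound 1

The compounds below may be only part of what the source reports. "The series", "measured", "known", "first", "only" and "open" are said of these compounds alone.

Measured so far in an ADME assay on L6 cells (Rattus norvegicus) for cytotoxicity, read by resazurin assay, with a stated time of 72 h (a higher number here means a weaker inhibitor, a lower number a stronger inhibitor), are three compounds:
compound 1 `OC(c1ccc(Cl)cc1)(c1cccnc1)c1ccc(Cl)cc1F` gives 59400 nM in this test
compound 2 `OC(c1ccc(Cl)cc1)(c1cccnc1)c1ccc(Br)cc1F` gives 79200 nM in this test
compound 3 `N#Cc1ccc(C(O)(c2ccc(Cl)cc2)c2cccnc2)c(F)c1` gives > 100000 nM as a limit of the assay

For the measured compounds named here, compound 1 holds one of only two actual numbers. The other belongs to compound 2, and the data show a 1.3-fold higher number from compound 1 to compound 2 (0.12 log units; within the scatter) between them, so the two cannot be told apart.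

Compound 4 `OC(c1cccnc1)(c1ccc(Cl)cc1F)c1ccc(Cl)cc1F` has not yet been measured. It differs from compound 1 by fluoro in place of hydrogen on an aromatic carbon in the form of fluoro in place of hydrogen on an aromatic carbon, which turns 4-chlorophenyl to 4-chloro-2-fluorophenyl.

Going by the values given here, no measured step makes this exact change. The nearest evidence comes from exchanges of one group for another on an aromatic carbon, which gave a 1.3-fold higher number from compound 1 to compound 2 (0.12 log units; within the scatter) and an at least 1.6-fold higher number from compound 1 to compound 3 (0.22 log units; that floor lies within the scatter) and also an at least 1.2-fold higher number from compound 2 to compound 3 (0.10 log units; that floor lies within the scatter) in the same series. The last two are floors only, and none of the three leaves the scatter. On that basis no step beyond the scatter is expected, and the estimate amounts to a 1.0-fold higher number from compound 1 to compound 4 (0.00 log units; within the scatter) as the expected change.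

Compound 4 is expected at 60000 nM with an estimated range from 30000 nM to 100000 nM as its likely span.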

Compound 4, half-maximal inhibitory concentration: 56300 nM
For compound 4 the middle estimate is 1.1-fold (0.03 log units) above the measured one; measured number inside the range.
By their numbers in this assay, from the lowest: compounds 4, 1 and 2 (each within the scatter of the next). At a limit, above all of these: compound 3.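

In this assay, the exchange that turns 4-chlorophenyl to 4-chloro-2-fluorophenyl gives a 1.1-fold lower number from compound 1 to compound 4 (0.02 log units; within the scatter). The earlier steps shown here only exchanged one group for another on an aromatic carbon, whereas this one puts fluoro in place of hydrogen, ortho to a large group and meta to a chloro group, and the number stays within the scatter, so compound 4 cannot be told apart from compound 1. Compound 3 remains at a limit of the assay, so it cannot be placed among the actual numbers and the comparison of fluoro with hydrogen says nothing about it: the limit of > 100000 nM in this assay, at which 1 of the 4 values shown sits.

What the compounds shown leave open is whether this place accepts only a single fluoro atom or whether a larger group, such as methoxy, an amine or a carboxylic acid, would also leave the number within the scatter. They also leave open whether any change to the shared core could bring the number in this assay clearly away from that of compound 1, since no step shown so far lies beyond the scatter.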